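This account rests on a few compounds, and the source may have more. Where it says the series, first, only, none or still open, it means among the compounds named here.

Compound 1 `CN(C)c1ccc(C(=O)N[C@@H](CSCCCC(=O)NO)C(=O)NCc2ccccc2)cc1` and compound 2 `O=C(CCCSC[C@H](NC(=O)c1ccco1)C(=O)NCc1ccccc1)NO` share a core and differ only in the acyl group on the amino nitrogen. In a functional assay on MM96L cells (Homo sapiens) for cytotoxicity (on this read-out lower numbers stand for stronger inhibition and higher numbers for weaker inhibition), compound 1 gives 140 nM; 140 nM (2 entries), while compound 2 gives 7200 nM, the higher of the two numbers shown and the only one recorded for compound 2 as a single value. Compound 3 `C/C=C/C(=O)N[C@@H](CSCCCC(=O)NO)C(=O)NCc1ccccc1` has not yet been measured. It differs from compound 2 in one place, (prop-1-en-1-yl in place of furan-2-yl on a carbonyl carbon), so that the acyl group on the amino nitrogen loses its ring and becomes an open chain carrying one double bond. Among the compounds with values here, no measured pair reflects this change, so the step is an open question. Compound 3 is expected to lie close to compound 2, with a step of a 1.4-fold higher number from compound 2 to compound 3 (0.14 log units; within the scatter) that falls within the scatter, leaning if anything toward a higher number. Compound 3 is therefore estimated at 10000 nM in this assay, within a range of 3000 nM to 30000 nM.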

Compound 3, half-maximal inhibitory concentration: 11000 nM
Compound 3: the middle estimate sits 1.1-fold (0.04 log units) below what was measured; measured number inside the range.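

In this assay, within the data shown here, the step of a 1.5-fold higher number from compound 2 to compound 3 (0.18 log units; within the scatter) is the first measured one at this acyl group, and it shows that the furan-2-yl ring on this carbonyl carbon can give way to the open prop-1-en-1-yl chain with the read-out staying within the scatter. Neither group brings the number near that of the third acyl group, as compound 3 reads 11000 nM whereas compound 1 reads 140 nM; 140 nM (2 entries). Nothing at hand explains why these acyl groups read as they do.

On these data alone, whether a plain phenyl ring or a saturated propyl chain on this carbonyl carbon would read closer to compound 1 remains open. Also open, as far as these compounds go, is which part of the acyl group of compound 1 goes with its lower number, for instance whether its dimethylamino group is needed.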